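Trifluoromethyl for Fluoro in a Cytotoxicity Assay

The compounds below may be only part of what the source reports. "The series", "measured", "known", "first", "only" and "open" are said of these compounds alone.

Measured compounds:
compound 1 `CC(=O)Nc1ccc2oc(-c3ccc(F)cc3)cc(=O)c2c1` — 22000 nM
compound 2 `CC(=O)Nc1ccc2oc(-c3ccc(C(F)(F)F)cc3)cc(=O)c2c1` — 10000 nM
compound 3 `Nc1ccc2oc(-c3ccc(F)cc3)c(O)c(=O)c2c1` — 4000 nM

Three compounds share an aryl group on a bicyclic core and were tested in an ADME assay on THP-1 cells (Homo sapiens) for cytotoxicity, read by flow cytometry and propidium iodide staining, with a stated time of 72 h; on this read-out higher numbers stand for weaker inhibition and lower numbers for stronger inhibition. Compound 1 gives 22000 nM and compound 2 gives 10000 nM. The two differ by trifluoromethyl in place of fluoro on an aromatic carbon, and this change produced a 2.2-fold lower number from compound 1 to compound 2 (0.34 log units; beyond the scatter). Compound 3 stands at 4000 nM, the lowest of the three numbers; its core differs from that of compound 1 in more than one place, and the difference between the two cores is not broken down here.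

Compound 4 `Nc1ccc2oc(-c3ccc(C(F)(F)F)cc3)c(O)c(=O)c2c1` has not yet been measured in this assay. It differs from compound 3 by trifluoromethyl in place of fluoro on an aromatic carbon, the same change that separates compound 1 from compound 2, made on the same kind of position. Among the measured compounds shown here, whether the core of compound 3 carries this change in the same way as the core of compound 1 is unknown, since only one earlier instance exists. The step from compound 3 to compound 4 is expected to be a 2.2-fold lower number from compound 3 to compound 4 (0.35 log units; beyond the scatter), because the earlier instance gave a 2.2-fold lower number from compound 1 to compound 2 (0.34 log units; beyond the scatter). Compound 4 is therefore estimated at 1800 nM in this assay. A range from 800 nM to 4500 nM is expected for compound 4, allowing for a step that could be smaller or larger on a different core.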

Compound 4, half-maximal inhibitory concentration: > 125000 nM
Compound 4 was reported as a limit; the forecaster's own chance of this, stated with the estimate: 3%; middle value at least 69-fold (1.84 log units) from the limit.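

In this assay, the same replacement of fluoro by trifluoromethyl on an aromatic carbon gave an at least 31-fold higher number from compound 3 to compound 4 (1.49 log units; beyond the scatter), a step in the opposite direction to the one seen earlier, so the change did not carry over from the core of compound 1 to the core of compound 3: the same change on two cores in this assay, a 2.2-fold lower number (0.34 log units; beyond the scatter) from compound 1 to compound 2 and an at least 31-fold higher number (1.49 log units; beyond the scatter) from compound 3 to compound 4, at least 68-fold (1.83 log units) apart, beyond the scatter of two such steps
The value of compound 4 is a limit of the assay and not a number, so the direction of the step can be read, but its true size cannot: the limit of > 125000 nM in this assay, at which 1 of the 4 values shown sits.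
The two cores differ in more than one place, and with a single pair on each, the result does not show which of those differences goes with the reversal, nor does it explain the reversal or show how any other core in the series would respond.

The compounds shown leave open how a core carrying only one of those differences would respond, for example one that keeps the acetamide and also bears the hydroxyl, or one that has the free amine without the hydroxyl. They also leave open whether a chloro or a methoxy group in place of the trifluoromethyl would follow compound 2 or compound 4 on each core.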